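The source may report more compounds than this note shows. Statements on the series, on what has been measured and on what is new or still open speak of the compounds shown alone.

In a physicochemical assay for lipophilicity, using the shake flask method, in phosphate buffer, measured as octanol-water partition, with a stated time of 30 min, at pH 7.4 (a lower number here means a more polar compound, a higher number a more lipophilic compound), compound 1 `CN(c1ncco1)c1cnc(NCc2c(F)ccc3c2CCO3)n2cnnc12` gives 2.1. Compound 2 `O=C1CCCN1c1cnc(NCc2c(F)ccc3c2CCO3)c2cn[nH]c(=O)c12` gives 1.8 in this assay, the lower of the two numbers, yet the gap to compound 1 lies within the usual scatter, so neither compound can be called the more polar. Compound 3 `Cc1cc(-c2cnc(NCc3c(F)ccc4c3CCO4)c3cn[nH]c(=O)c23)n(C)n1` has not yet been measured. For the measured compounds named here, it differs from compound 2 in one place: 1,3-dimethyl-1H-pyrazol-5-yl in place of 2-oxopyrrolidin-1-yl on an aromatic carbon With no step between measured compounds to lean on, the expectation rests on the change alone: a rise beyond the scatter is expected, a number 0.70 log units higher from compound 2 to compound 3 (beyond the scatter). For compound 3 the estimate is 2.5, with a range from 2 to 3.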

Compound 3, distribution coefficient: 3
Compound 3: the middle estimate sits 0.50 log units below what was measured; the range from low to high includes it.
By their numbers in this assay, from the lowest: compounds 2 and 1 (each within the scatter of the next); then compound 3.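

Putting 1,3-dimethyl-1H-pyrazol-5-yl in place of 2-oxopyrrolidin-1-yl gives a number 1.20 log units higher from compound 2 to compound 3 (beyond the scatter) in this assay on this aromatic carbon. For the compounds shown here, the earlier compounds offered no step, so this is the first sign that the group here can move the number beyond the scatter. No measurement at hand says what lies behind this rise.

The compounds shown leave open whether the methyl groups or the pyrazole ring itself carry the step. From the compounds shown here alone, how an amine or a carboxylic acid on this carbon would read also remains open.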